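A few compounds are considered here, and "the series" means these few. Any claim that something is new, unique, unknown or untested is made for them only; others in the source may bear on it.

Of the compounds shown here, three built on one shared core have been tested in a functional assay on A549 cells (Homo sapiens) for inhibition, read by sulforhodamine B assay, with a stated time of 48 h, tested at 50 uM; on this read-out lower numbers stand for less inhibition of growth and higher numbers for more inhibition of growth at the one concentration tested. Compound 1 `COc1cc2c(cc1CC=C(C)C)C(=O)C[C@@H](c1ccc(Oc3ccccc3)cc1)O2` carries a phenyl on an oxygen on an aromatic ring, and in this assay compound 1 gives 46% at the single concentration used. Compound 2 `CCOc1ccc([C@@H]2CC(=O)c3cc(CC=C(C)C)c(OC)cc3O2)cc1` carries an ethyl on that oxygen, and compound 2 gives 37% there. Compound 3 `COc1cc2c(cc1CC=C(C)C)C(=O)C[C@@H](c1ccc(Oc3cccc([N+](=O)[O-])c3)cc1)O2` carries a 3-nitrophenyl on the same oxygen, and compound 3 gives 37% in this assay. The three numbers sit close together: a number 9 percentage points lower from compound 1 to compound 2 (within the scatter), a number 9 percentage points lower from compound 1 to compound 3 (within the scatter) and no change at the digits printed from compound 2 to compound 3 (within the scatter) are all steps that stay inside the usual scatter. Compound 3 thus stands level with compound 2 at the digits shown and within the scatter of compound 1.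

Compound 4 `COc1ccc([C@@H]2CC(=O)c3cc(CC=C(C)C)c(OC)cc3O2)cc1` has not yet been measured. It differs from compound 3 in one place: methyl in place of 3-nitrophenyl on an oxygen on an aromatic ring. Cut one bond further out, the difference reads 3-nitrophenoxy to methoxy. The step that bears most directly on it is the one between compound 2 and compound 3, where an ethyl on this oxygen gave way to a 3-nitrophenyl with no change at the digits shown, and methyl and ethyl are both short chains. Among the compounds with values here, since no step among the measured compounds moved this assay beyond the scatter, no step beyond the scatter is expected here either. Compound 4 is therefore expected to give 38%, within a range from 24% to 52% in this assay. The step this estimate implies is expected to be a number 1 percentage points higher from compound 3 to compound 4 (within the scatter) in this assay.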

Compound 4, percent growth inhibition at one concentration: 45%
Beside the measured number, compound 4's estimate is 7 percentage points below it, and the stated range covers the measured number.
By their numbers in this assay, from the lowest: compounds 2, 3, 4 and 1 (each within the scatter of the next).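

Within the data shown here, at the oxygen on an aromatic ring, a very large change in the attached group makes no difference beyond the scatter in this assay: swapping the 3-nitrophenyl, with its 9 heavy atoms, for a methyl of a single carbon gives a number 8 percentage points higher from compound 3 to compound 4 (within the scatter) and is no larger than the earlier steps. The two remaining comparisons agree, with the ethyl-to-methyl change giving a number 8 percentage points higher from compound 2 to compound 4 (within the scatter) and the phenyl-to-methyl change giving a number 1 percentage points lower from compound 1 to compound 4 (within the scatter), so methyl, ethyl, phenyl and 3-nitrophenyl cannot be told apart on this oxygen in this read-out. Nothing available explains why these four groups read alike.

On these data alone, whether a free hydroxyl, a longer chain such as butyl, or a phenyl ring carrying an amine or a carboxylic acid on this oxygen would move the number beyond the scatter remains open. As far as these compounds go, each compound also has a number at only one concentration, so how these four would compare across a range of concentrations is still unknown.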